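Aryl sulfonyl variation on the shared core

A few compounds are considered here, and "the series" means these few. Any claim that something is new, unique, unknown or untested is made for them only; others in the source may bear on it.

Among the compounds with values here, compound 1 `CN1CCN(c2ccc3[nH]nc(S(=O)(=O)c4ccc(F)cc4)c3c2)CC1` and compound 2 `CN1CCN(c2cccc3c(S(=O)(=O)c4cccc5ccccc45)n[nH]c23)CC1` are the two measured members so far. In an assay on HeLa cells for displacement of a labelled ligand from 5-hydroxytryptamine receptor 6 (Homo sapiens) (a higher number here means a weaker inhibitor, a lower number a stronger inhibitor), compound 1 gives 5.2 nM, and compound 2 gives 4.6 nM. The two values lie within the scatter of each other, so compound 1 stands with the higher of the two numbers without any order between them being readable.

Compound 3 `COc1ccc(S(=O)(=O)c2n[nH]c3ccc(N4CCN(C)CC4)cc23)cc1` is the next to be measured in this assay. It differs from compound 1 in one place: methoxy in place of fluoro on an aromatic carbon. Within the data shown here, no step between measured compounds covers this change, so nothing in the present data fixes its direction or size. The expectation is a step from compound 1 to compound 3 of no more than the scatter, in either direction. Compound 3 is expected to give 5.5 nM, within a range from 2 nM to 15 nM. The step of a 1.1-fold higher number from compound 1 to compound 3 (0.02 log units; within the scatter) is expected to stay within the scatter.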

Compound 3, inhibition constant: 12 nM
Beside the measured number, compound 3's estimate is 2.2-fold (0.34 log units) below it; measured number inside the range.
By their numbers in this assay, from the lowest: compounds 2 and 1 (each within the scatter of the next); then compound 3.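

In this assay, within the data shown here, going from 4-fluorophenyl to 4-methoxyphenyl gives a 2.3-fold higher number from compound 1 to compound 3 (0.36 log units; beyond the scatter), the only step so far that can be read at a single position. The step lies beyond the scatter, though only modestly, so this aromatic carbon para to a large group is not indifferent to the group it carries, and fluoro is the better of the two groups compared here. No measurement in hand bears on the origin of this step.

On these data alone, whether the higher number belongs to methoxy alone or extends to other groups at this position, such as chloro, an amine, a nitrile or a longer alkoxy chain, stays open. So does the reading of the unsubstituted phenyl, which would show which of the two groups moves the number away from the plain ring.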